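Bromo for methoxy: transfer of one change across cores

This account rests on a few compounds, and the source may have more. Where it says the series, first, only, none or still open, it means among the compounds named here.

Measured compounds, in a functional assay on A549 cells (Homo sapiens) for antiproliferative activity, read by MTT assay; on this read-out lower numbers stand for stronger inhibition and higher numbers for weaker inhibition:
compound 1, `COc1ccc(-c2ccnc(Nc3ccc([N+](=O)[O-])cc3)n2)cc1`: 2730 nM
compound 2, `O=[N+]([O-])c1ccc(Nc2nccc(-c3ccc(Br)cc3)n2)cc1`: 76000 nM
compound 3, `COc1ccc(-c2ccnc(Nc3cccc(OC)c3)n2)cc1`: 6530 nM

Compound 1 and compound 2 differ in one place, (bromo in place of methoxy on an aromatic carbon). That change gives a 28-fold higher number from compound 1 to compound 2 (1.44 log units; beyond the scatter), a marked loss of antiproliferative activity within this pair.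

Compound 3 carries the same methoxy group on the same ring as compound 1, but its core is different; the difference between the two cores is not broken down here. In this assay compound 3 sits between the other two: compared with compound 1 it gives a higher number, and compared with compound 2 a clearly lower one, both gaps beyond the scatter.

Compound 4, `COc1cccc(Nc2nccc(-c3ccc(Br)cc3)n2)c1`, is not yet measured. It stands to compound 3 as compound 2 stands to compound 1: bromo in place of methoxy on an aromatic carbon. The place lines of the two changes read the same word for word, so this is the same change, made on a second core.

The expectation for compound 4 rests on a single precedent, the step from compound 1 to compound 2 with its size a 28-fold higher number from compound 1 to compound 2 (1.44 log units; beyond the scatter). Among the compounds with values here, whether a change of that size carries over onto the core of compound 3 is untested, since only one pair shows it. The step from compound 3 to compound 4 is therefore expected at about a 15-fold higher number from compound 3 to compound 4 (1.19 log units; beyond the scatter) in this assay, taken with a wide margin. Compound 4 is accordingly estimated at 100000 nM, with a likely range from 25000 nM to 300000 nM, and with a real chance that only a limit is reported.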

Compound 4, half-maximal inhibitory concentration: 82700 nM
Compound 4: middle estimate off by 1.2-fold (0.08 log units), on the high side, within the range that was stated.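

In this assay, bromo in place of methoxy on an aromatic carbon again gives a large loss of antiproliferative activity on the second core, with a 13-fold higher number from compound 3 to compound 4 (1.10 log units; beyond the scatter). Set beside the earlier step, the change carries over from one core to the other in direction and, within the scatter, in size: the same change on two cores in this assay, a 28-fold higher number (1.44 log units; beyond the scatter) from compound 1 to compound 2 and a 13-fold higher number (1.10 log units; beyond the scatter) from compound 3 to compound 4, 2.2-fold (0.34 log units) apart, within the scatter of two such steps. This rests on two pairs only, so it supports transfer between the core of compound 1 and the core of compound 3 but gives no general rule for the series, says nothing about a further core, and does not explain why the step has this size.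

The compounds shown carry only methoxy and bromo at this place, so it remains open whether the loss follows the departure of methoxy or the arrival of bromo, a question that chloro, hydroxy or an amine at the same place could help to settle. Also open, from the compounds shown here alone, is whether the step keeps its size when the second aromatic ring, which so far bears nitro or methoxy, carries instead a carboxylic acid or a longer chain.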